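The source may report more compounds than this note shows. Statements on the series, on what has been measured and on what is new or still open speak of the compounds shown alone.

Series notes. Compound 1 `C=CCNC(=O)/C(C)=C(\C)c1ccc(OC)cc1`, compound 2 `C=CCNC(=O)/C(C)=C(\C)c1ccc(C)cc1` and compound 3 `C/C(C(=O)NC1CC1)=C(/C)c1ccc(C)cc1` have been run in a toxicity assay on the whole organism (strain Icem-CET (SPF Caw)) for cytotoxicity, with Mus musculus as the target; a lower number here means that less compound is needed, a higher number that more compound is needed for the effect; compound 4 `COc1ccc(/C(C)=C(\C)C(=O)NC2CC2)cc1` has not. In this assay compound 1 gives 200 mg/kg, compound 2 gives 100 mg/kg and compound 3 gives 110 mg/kg.

The change from compound 3 to compound 4 is methoxy in place of methyl on an aromatic carbon. The same change, on the same place, is seen once already: methoxy in place of methyl on an aromatic carbon, where it made a 2.0-fold higher number from compound 2 to compound 1 (0.30 log units; within the scatter). The cores of compound 2 and compound 3 differ in cyclopropyl in place of allyl on an amide-type nitrogen, a change that made a 1.1-fold higher number from compound 2 to compound 3 (0.04 log units; within the scatter).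

For compound 4, the step in this assay is expected to come out as a 1.7-fold higher number from compound 3 to compound 4 (0.24 log units; within the scatter), resting on the earlier methoxy-for-methyl step of compound 2 to compound 1 with its a 2.0-fold higher number from compound 2 to compound 1 (0.30 log units; within the scatter). Compound 4 is thus estimated at 190 mg/kg in this assay, in the range 100 mg/kg to 360 mg/kg.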

Compound 4, dose for half-maximal effect: 250 mg/kg
Estimate against measurement, compound 4: 1.3-fold (0.12 log units) below, and the stated range covers the measured number.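

In this assay, methoxy in place of methyl on an aromatic carbon carries over to the cyclopropyl amide core with a 2.3-fold higher number from compound 3 to compound 4 (0.36 log units; beyond the scatter), and the two steps agree: the same change on two cores in this assay, a 2.0-fold higher number (0.30 log units; within the scatter) from compound 2 to compound 1 and a 2.3-fold higher number (0.36 log units; beyond the scatter) from compound 3 to compound 4, 1.1-fold (0.06 log units) apart, within the scatter of two such steps

Cyclopropyl in place of allyl on an amide-type nitrogen likewise reads the same on both aromatic substituents, with a 1.3-fold higher number from compound 1 to compound 4 (0.10 log units; within the scatter): the same change on two cores in this assay, a 1.1-fold higher number (0.04 log units; within the scatter) from compound 2 to compound 3 and a 1.3-fold higher number (0.10 log units; within the scatter) from compound 1 to compound 4, 1.1-fold (0.06 log units) apart, within the scatter of two such steps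

For the compounds shown here, this shows that both changes transfer within these four compounds, but with only two cores per change it does not show that they would transfer to any other core, and it gives no reason for the agreement.

Open, going by these compounds, is how a chlorine or a carboxylic acid on the same aromatic carbon would behave. Also open, on these data alone, is whether the methoxy step holds with a longer chain on the amide nitrogen.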